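From Heptyl to Cyclohexyl at the Aromatic Nitrogen

The compounds below may be only part of what the source reports. "The series", "measured", "known", "first", "only" and "open" are said of these compounds alone.

Three measured compounds share one core. Compound 1 `Cn1nc(-c2cccnc2)c2ccccc2c1=O` gives 63% in an assay on isolated protein (Oryctolagus cuniculus) with Thromboxane-A synthase (Homo sapiens) as the target, tested at 1 uM; a lower number here means less inhibition, a higher number more inhibition at the concentration tested (going by the name of the read-out); compound 2 `CCn1nc(-c2cccnc2)c2ccccc2c1=O` gives 87%; compound 3 `CCCCCCCCn1nc(-c2cccnc2)c2ccccc2c1=O` gives 99%. Compound 3 stands highest of the three. The steps of a number 36 percentage points higher from compound 1 to compound 3 (beyond the scatter) and a number 12 percentage points higher from compound 2 to compound 3 (beyond the scatter) both lie beyond the scatter, and a number 24 percentage points higher from compound 1 to compound 2 (beyond the scatter) shows that each lengthening of the chain raised inhibition. Compound 4 `O=c1c2ccccc2c(-c2cccnc2)nn1CC1CCCCC1` carries cyclohexyl in place of heptyl on a saturated chain carbon bound to an aromatic nitrogen. The steps from smaller to larger groups bear on this change; they were modest to large, and the number for compound 3 is already high, leaving little room upward. A step of about a number 4 percentage points lower from compound 3 to compound 4 (within the scatter) is therefore expected, within the scatter. Compound 4 is estimated at 95%, between 85% and 100%.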

Compound 4, a percentage reported as inhibition, at one concentration (the size of the read-out at that concentration, not a potency): 98%
Beside the measured number, compound 4's estimate is 3 percentage points below it; low and high end bracket the measured number.
By their numbers in this assay, from the lowest: compound 1; then compound 2; then compounds 4 and 3 (each within the scatter of the next).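

In this assay, a ring serves as well as an open chain at this place: cyclohexyl in place of heptyl gives a number 1 percentage points lower from compound 3 to compound 4 (within the scatter), so the two cannot be told apart. The ring also keeps the gains over the smaller groups, with a number 11 percentage points higher from compound 2 to compound 4 (beyond the scatter) and a number 35 percentage points higher from compound 1 to compound 4 (beyond the scatter). Nothing measured here explains these results. As far as these compounds go, whether a phenyl ring or an amine on the chain would hold this level stays open. Readings this high, taken at one concentration, also leave open whether compound 3 and compound 4 differ in potency.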